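Notes on a sulfonyl quinoline series: clearance in human microsomes

This account rests on a few compounds, and the source may have more. Where it says the series, first, only, none or still open, it means among the compounds named here.

Measured so far:
compound 1 `COc1cccc(S(=O)(=O)c2cnc3cc(F)ccc3c2-c2cccc(Cl)c2)c1` — 2.97 mL/min
compound 2 `COc1cccc(S(=O)(=O)c2cnc3cc(F)ccc3c2-c2cccc(F)c2)c1` — 3.36 mL/min
compound 3 `COc1ccc(S(=O)(=O)c2cnc3c(F)cccc3c2-c2cccc(Cl)c2)cc1` — 2.75 mL/min

In an ADME assay on microsomes from liver (Homo sapiens) for metabolic stability, tested at 2.5 uM (a higher number here means faster removal of the compound, a lower number slower removal), compound 2 gives 3.36 mL/min. Compound 2 holds the highest of the three numbers, yet the gaps to both others are within the scatter: compound 1 gives 2.97 mL/min and compound 3 gives 2.75 mL/min, so the three compounds cannot be separated on this read-out.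

The next compound, compound 4 `N#Cc1cccc(S(=O)(=O)c2cnc3cc(F)ccc3c2-c2cccc(F)c2)c1`, is not yet measured in this assay. It differs from compound 2 at the ring that carries the sulfonyl group: cyano in place of methoxy on an aromatic carbon

Of the measured steps, only a 1.1-fold higher number from compound 1 to compound 2 (0.05 log units; within the scatter) is defined, and it concerns the other phenyl ring, not the one altered here. Going by the values given here, no measured step involves an exchange of methoxy for cyano, so nothing bears directly on the change. The unrelated step and the spread across compounds 1, 2 and 3 all lie within the scatter, which gives no reason to expect a step in this assay beyond the scatter in either direction, though the range must be kept wide.

Compound 4 is therefore estimated at 3 mL/min, with a range from 1.4 mL/min to 6.5 mL/min. This expectation corresponds to a step of a 1.1-fold lower number from compound 2 to compound 4 (0.05 log units; within the scatter).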

Compound 4, intrinsic clearance in a liver preparation (reported as CLH), per the amount of preparation that the assay uses: 0.78 mL/min
Compound 4: middle estimate off by 3.8-fold (0.59 log units), on the high side; the whole stated range lies above it.
By their numbers in this assay, from the lowest: compound 4; then compounds 3, 1 and 2 (each within the scatter of the next).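

In this assay, 3-cyanophenyl in place of 3-methoxyphenyl gives a 4.3-fold lower number from compound 2 to compound 4 (0.63 log units; beyond the scatter), the only step shown so far that lies beyond the scatter. Going by these compounds alone, the ring that carries the sulfonyl group is therefore a place where this read-out responds to a change of a single group, which the earlier compounds could not show: their one defined step, a 1.1-fold higher number from compound 1 to compound 2 (0.05 log units; within the scatter), concerns the other phenyl ring and stays within the scatter. The exchange keeps the counts of heavy atoms and hydrogen-bond acceptors unchanged, so those counts do not separate the two groups, and nothing in hand accounts for the difference between methoxy and cyano.

As far as these compounds go, it remains open whether the lower number comes with the cyano group itself or simply with the loss of methoxy; a plain hydrogen, a chloro group or a carboxylic acid at the same place would help to separate these two readings. From the compounds shown here alone, it also remains open whether the same exchange gives a step of this size with chloro on the other phenyl ring, as in compound 1.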